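A Lactam Substituent Enters the Pyrazolopyridinone Series

The source may report more compounds than this note shows. Statements on the series, on what has been measured and on what is new or still open speak of the compounds shown alone.

Compound 3 `CNC(=O)c1ccc(-c2cnc(NCc3c(F)ccc4c3CCO4)c3cn[nH]c(=O)c23)c(C)n1` was measured in an ADME assay on microsomes from liver (Homo sapiens) for metabolic stability, read by LC-MS, using NADPH, with stated times of 5 min and 30 min, tested at 1 uM (a higher number here means faster removal of the compound, a lower number slower removal), and gives 23 mL.min-1.g-1. Among the three compounds measured, compound 3 stands second highest: its nearest neighbour is compound 2 `Cn1cc(-c2cnc(NCc3c(F)ccc4c3CCO4)c3cn[nH]c(=O)c23)cn1`, which gives 21 mL.min-1.g-1, with a 1.1-fold higher number from compound 2 to compound 3 (0.04 log units; within the scatter); the furthest is compound 1 `CN(c1ccn(C)n1)c1cnc(NCc2c(F)ccc3c2CCO3)c2cn[nH]c(=O)c12`, which gives 62 mL.min-1.g-1, with a 2.7-fold lower number from compound 1 to compound 3 (0.43 log units; beyond the scatter). Compound 4 `O=C1CCCN1c1cnc(NCc2c(F)ccc3c2CCO3)c2cn[nH]c(=O)c12` has not yet been measured. It differs from compound 3 in one place: 2-oxopyrrolidin-1-yl in place of 2-methyl-6-(methylcarbamoyl)pyridin-3-yl on an aromatic carbon.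

For the measured compounds named here, none of the measured steps exchanges the departing group for a 2-oxopyrrolidin-1-yl, so no step bears on it directly. What is known is that compound 2 and compound 3, which carry different aromatic groups at this position, lie within the scatter of each other, while compound 1, with a 3.0-fold lower number from compound 1 to compound 2 (0.47 log units; beyond the scatter), sits apart. Compound 4 is therefore expected to fall near compound 3, with a 1.2-fold lower number from compound 3 to compound 4 (0.06 log units; within the scatter) not beyond the scatter. The estimate for compound 4 is 20 mL.min-1.g-1, with a range from 8 mL.min-1.g-1 to 50 mL.min-1.g-1.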

Compound 4, intrinsic clearance in microsomes: 23 mL.min-1.g-1
Compound 4: middle estimate off by 1.2-fold (0.06 log units), on the low side; measured number inside the range.
By their numbers in this assay, from the lowest: compounds 2, 3 and 4 (each within the scatter of the next); then compound 1.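

In this assay, the result shows that this position does not need an aromatic group to give the level seen with compound 2 and compound 3: the non-aromatic 2-oxopyrrolidin-1-yl gives no change at the digits printed from compound 3 to compound 4 (within the scatter) and a 1.1-fold higher number from compound 2 to compound 4 (0.04 log units; within the scatter), although it is a smaller group than 2-methyl-6-(methylcarbamoyl)pyridin-3-yl and has no hydrogen-bond donor. It also shows that joining the group to the core through nitrogen does not by itself go with the high number of compound 1, since the lactam, also joined through nitrogen, gives a 2.7-fold lower number from compound 1 to compound 4 (0.43 log units; beyond the scatter). The data shown offer no explanation for either observation.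

From the compounds shown here alone, it remains open whether the six-membered lactam piperidin-2-one or an open-chain acetamide would stay at this level. Going by these compounds, it is equally open whether a simple dimethylamino group would stay there or instead lie nearer compound 1.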